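The compounds below may be only part of what the source reports. "The series", "measured", "known", "first", "only" and "open" are said of these compounds alone.

In a functional assay on T47D cells (Homo sapiens) for cytotoxicity, read by MTT assay, with a stated time of 2 days (on this read-out lower numbers stand for stronger inhibition and higher numbers for weaker inhibition), three compounds have been measured so far. Compound 1 `Cc1cccc(-c2nc3cc(C)ccc3c(=O)[nH]2)c1` gives > 50000 nM as its reading, and this is a limit of the assay, not a number. Compound 3 `Cc1cccc(-c2nc3ccc(C)cc3c(=O)[nH]2)c1` gives > 50000 nM as its reading, which is again only a limit. For the measured compounds named here, compound 2 `COc1cccc(-c2nc3ccc(N4CCCCC4)cc3c(=O)[nH]2)c1OC` gives 10400 nM as the one true number in the set. Compound 3 therefore has no exact place on the scale, and what the data offer is the limit of > 50000 nM in this assay, at which 2 of the 3 values shown sit, and nothing finer.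

The next compound to be tested is compound 4 `Cc1ccc2nc(-c3cccc(F)c3)[nH]c(=O)c2c1`. The change from compound 3 is fluoro in place of methyl on an aromatic carbon, meta to a large group, counted as fluoro in place of methyl on an aromatic carbon in full. Going by the values given here, no two measured compounds here differ in only one place, so there is no direct guide to this swap. In this assay the expected step is none beyond the usual scatter, with no favoured direction, and compound 4 may well read as a limit too. The estimated move is a number no higher from compound 3 to compound 4 (the limit leaves the size open) as a rough expectation only. For compound 4 the estimate is 50000 nM within an expected range from 20000 nM to 100000 nM if a number is reported at all.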

Compound 4, half-maximal inhibitory concentration: > 50000 nM
Compound 4 gave a limit, no number; the forecaster's own chance of this, stated with the estimate: 65%; the middle value lies on the limit itself.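

In this assay, compound 3 and compound 4 both end at a limit rather than a true number, so no step can be read between them: the limit of > 50000 nM in this assay, at which 3 of the 4 values shown sit. The compounds shown leave open whether fluoro in place of methyl on an aromatic carbon changes the reading at all, and if so, in which direction and by how much.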